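The source may hold more compounds than are shown below. What is called first, only, known or untested is meant among the compounds shown, and "the series" means these compounds.

Measured so far:
Compound 1, `CCC1(Cc2ccccc2)OS(=O)(=O)C=C1OCC1CCCCC1`, in an ADME assay on HEL cells (Homo sapiens) for cytotoxicity, with a stated time of 3 days (a lower number here means that less compound is tolerated, a higher number that more compound is tolerated), gives > 200000 nM, which is a limit of the assay and not a number.
Compound 2, `CCC1(Cc2ccccc2)OS(=O)(=O)C=C1OCc1ccc([N+](=O)[O-])cc1`, in this assay gives < 200000 nM, again a limit rather than a number.
Compound 3, `CCC1(Cc2ccccc2)OS(=O)(=O)C=C1OCc1cccc(Cl)c1`, in this assay gives 50000 nM.

Compound 3 therefore stands as the only compound with an actual number; the other two values are limits, as shown by the limit of < 200000 nM in this assay, at which 1 of the 3 values shown sits, and (the limit of > 200000 nM in this assay, at which 1 of the 3 values shown sits). The next compound, compound 4, `CCC1(Cc2ccccc2)OS(=O)(=O)C=C1OC(=O)c1ccccc1`, is not yet measured. It differs from compound 3 by benzoyl in place of 3-chlorobenzyl on an oxygen on an unsaturated carbon.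

Of the measured steps, the only one with a readable size is an at least 4.0-fold lower number from compound 1 to compound 3 (0.60 log units; beyond the scatter). The step of a number no higher from compound 1 to compound 2 (the limit leaves the size open) and the step that the limit leaves unreadable from compound 2 to compound 3 do not give a size. All three swap a group on a saturated chain carbon, whereas the change to compound 4 replaces the whole benzyl unit with a benzoyl directly on the oxygen, so none of them bears closely on it. With so little guidance, the expected step in this assay from compound 3 to compound 4 is none beyond the scatter, no change at the digits printed from compound 3 to compound 4 (within the scatter). Compound 4 is estimated at 50000 nM, within a range from 15000 nM to 200000 nM.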

Compound 4, half-maximal cytotoxic concentration: > 200000 nM
Compound 4: only a limit was reported; the forecaster's own chance of this, stated with the estimate: 30%; middle value at least 4.0-fold (0.60 log units) from the limit.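

In this assay, benzoyl in place of 3-chlorobenzyl on an oxygen on an unsaturated carbon gives an at least 4.0-fold higher number from compound 3 to compound 4 (0.60 log units; beyond the scatter), so at this position more compound is tolerated once a carbonyl sits directly on that oxygen. Both groups hold one six-membered aromatic ring of carbon only and have the same number of heavy atoms, so the presence of such a ring does not by itself bring the lower number seen for compound 3. The value of compound 4 is a limit of the assay and not a number, and it shares that limit with compound 1, so the step between them cannot be read, and the true size of the step to compound 4 stays open at its upper end: the limit of > 200000 nM in this assay, at which 2 of the 4 values shown sit.

This change removes the chlorine and adds the carbonyl in one move, so the compounds shown cannot say which of the two accounts for the step. An unsubstituted benzyl group or a 3-chlorobenzoyl group on the same oxygen would separate them, and a shorter acetyl group would show whether the aromatic ring is needed at all.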